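The compounds below may be only part of what the source reports. "The series", "measured", "known", "first", "only" and "open" are said of these compounds alone.

For the measured compounds named here, compound 1 `CCCCCCCC/C=C\CCCCCCC(=O)c1nc2cnccc2o1` is the only compound here with a number in an assay on isolated protein for inhibition of Fatty-acid amide hydrolase 1 (Homo sapiens); on this read-out higher numbers stand for weaker inhibition and lower numbers for stronger inhibition: compound 1 gives 7.2 nM. Compound 2 `CCCCCCCC/C=C\CCCCCCC(=O)c1nc(-c2ccccc2)c(-c2ccccc2)o1` reaches only the limit of this assay, > 100000 nM, and is not a number; this is the limit of > 100000 nM in this assay, at which 1 of the 2 values shown sits. Compound 3 `CCCCCCCC/C=C\CCCCCCC(=O)c1cccnn1` differs from compound 1 by one change: a group of 6 heavy atoms (4 carbon, 2 nitrogen; one six-membered aromatic ring with 2 hetero atoms) in place of a group of 9 heavy atoms (6 carbon, 2 nitrogen, 1 oxygen; one five-membered aromatic ring with 2 hetero atoms, one six-membered aromatic ring with 1 hetero atom), on a carbonyl carbon. Going by the values given here, no measured pair shows how such a change plays out, so the step from compound 1 to compound 3 in this assay is expected to be a 28-fold higher number from compound 1 to compound 3 (1.44 log units; beyond the scatter), a loss beyond the scatter. Compound 3 is therefore estimated at 200 nM, with a range from 40 nM to 1000 nM.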

Compound 3, inhibition constant: 130 nM
The estimate for compound 3 lay 1.5-fold (0.19 log units) above the measured number; low and high end bracket the measured number.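

Putting pyridazin-3-yl on the carbonyl carbon in place of the larger two-ring group gives an 18-fold higher number from compound 1 to compound 3 (1.26 log units; beyond the scatter) in this assay, a large loss. Even so, compound 3 keeps a measured number, so on this read-out inhibition does not depend on the five-membered ring of compound 1.

The compounds shown leave open whether an amine or a carboxylic acid on the pyridazin-3-yl group would win back any of this loss, and how a longer chain would behave with this group. Nothing shown bears on why the step is this large.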